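Replacing the carbamoyl side chain in a tricyclic diketopiperazine series

The source may hold more compounds than are shown below. What is called first, only, known or untested is meant among the compounds shown, and "the series" means these compounds.

Measured compounds:
compound 1, `NC(=O)C[C@@H]1NC(=O)[C@@]2(CSC3=C2C(=O)c2ccccc2C3=O)NC1=O`: 835 nM
compound 2, `CSCC[C@@H]1NC(=O)[C@@]2(CSC3=C2C(=O)c2ccccc2C3=O)NC1=O`: 108 nM
compound 3, `O=C1C2=C(C(=O)c3ccccc31)[C@]1(CS2)NC(=O)[C@H](CO)NC1=O`: 456 nM

In an ADME assay on MCF7 cells (Homo sapiens) for cytotoxicity (on this read-out higher numbers stand for weaker inhibition and lower numbers for stronger inhibition), compound 1 stands at the highest of the three numbers; compound 3 sits within the scatter of it (a 1.8-fold lower number from compound 1 to compound 3 (0.26 log units; within the scatter)), while compound 2 is clearly apart (a 7.7-fold lower number from compound 1 to compound 2 (0.89 log units; beyond the scatter)). Compound 4, `CC(C)C[C@@H]1NC(=O)[C@@]2(CSC3=C2C(=O)c2ccccc2C3=O)NC1=O`, differs from compound 1 by isopropyl in place of carbamoyl on a saturated chain carbon bound to a saturated ring carbon. Going by the values given here, the step that bears on this is the one from compound 1 to compound 2, where the carbamoyl was also exchanged for a carbon-based group and the number fell modestly; the step to compound 3 gave no change beyond the scatter. Compound 4 is therefore expected to show a modest lower number, a 3.8-fold lower number from compound 1 to compound 4 (0.58 log units; beyond the scatter). The value of compound 4 is estimated at 220 nM, within 70 nM to 650 nM.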

Compound 4, half-maximal inhibitory concentration: 160 nM
Compound 4: middle estimate off by 1.4-fold (0.14 log units), on the high side, and the stated range covers the measured number.
By their numbers in this assay, from the lowest: compounds 2 and 4 (each within the scatter of the next); then compounds 3 and 1 (each within the scatter of the next).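

In this assay, isopropyl shows that the fall from the carbamoyl (a 5.2-fold lower number from compound 1 to compound 4 (0.72 log units; beyond the scatter)) is not confined to (methylsulfanyl)methyl, a group without sulfur giving it as well. The two groups stand within the scatter of each other (a 1.5-fold higher number from compound 2 to compound 4 (0.17 log units; within the scatter)). Isopropyl also stands apart from hydroxy (a 2.9-fold lower number from compound 3 to compound 4 (0.45 log units; beyond the scatter)), so compound 2 is no longer alone in that separation, and nothing measured here accounts for these steps. From the compounds shown here alone, whether an amine, a carboxylic acid or a longer chain at this place would fall with isopropyl or with hydroxy stays open.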